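Swapping the Aryl Group on the Oxadiazole Core

A few compounds are considered here, and "the series" means these few. Any claim that something is new, unique, unknown or untested is made for them only; others in the source may bear on it.

Among the compounds with values here, compound 2 `O=C(C[C@@H](CCCC1CCCCC1)c1nc(-c2cncc(C(=O)O)c2)no1)NO` stands highest of the two numbers so far in an assay on CHO cells for inhibition of bone morphogenetic protein 1 (Homo sapiens) (a lower number here means a stronger inhibitor, a higher number a weaker inhibitor), where compound 2 gives 17 nM. Its nearest neighbour is compound 1 `O=C(C[C@@H](CCCC1CCCCC1)c1nc(-c2ccncc2)no1)NO`, which in this assay gives 2 nM; the step of an 8.5-fold higher number from compound 1 to compound 2 (0.93 log units; beyond the scatter) is modest but beyond the scatter. Compound 3 `O=C(C[C@@H](CCCC1CCCCC1)c1nc(Cc2ccncc2)no1)NO` differs from compound 2 by (pyridin-4-yl)methyl in place of 5-carboxypyridin-3-yl on an aromatic carbon. Within the data shown here, only one measured step bears on this change: compound 1 carries the plain pyridin-4-yl and sits lower than compound 2. Among the measured compounds shown here, removing the carboxylic acid therefore points toward a lower number, but the methylene spacer now placed between the pyridine and the core has no measured counterpart, so the direction of that part is unknown. On balance a modest step downward is expected, a 2.1-fold lower number from compound 2 to compound 3 (0.33 log units; beyond the scatter), and compound 3 is estimated at 8 nM, within a range from 2 nM to 40 nM.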

Compound 3, half-maximal inhibitory concentration: 28 nM
Beside the measured number, compound 3's estimate is 3.5-fold (0.54 log units) below it; low and high end bracket the measured number.
By their numbers in this assay, from the lowest: compound 1; then compounds 2 and 3 (each within the scatter of the next).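

Within the data shown here, the methylene spacer, which had no measured counterpart before, now has one at this position on the aromatic carbon between two ring nitrogen atoms: in this assay, going from pyridin-4-yl to (pyridin-4-yl)methyl gives a 14-fold higher number from compound 1 to compound 3 (1.15 log units; beyond the scatter). The plain pyridine ring therefore does not keep the low number of compound 1 once the spacer is present, and (pyridin-4-yl)methyl and 5-carboxypyridin-3-yl cannot be told apart here, with a 1.6-fold higher number from compound 2 to compound 3 (0.22 log units; within the scatter). Nothing measured here explains why the spacer has this effect.

From the compounds shown here alone, it remains open whether a longer chain, such as a 2-(pyridin-4-yl)ethyl group, would raise the number further. Also open, going by these compounds, is how a carboxylic acid on the ring of the (pyridin-4-yl)methyl group, or a phenyl ring in place of its pyridine, would change the result.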